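Notes on a cytotoxicity series, compound 1 to compound 4

The compounds below may be only part of what the source reports. "The series", "measured", "known", "first", "only" and "open" are said of these compounds alone.

Measured so far:
compound 1 `O=C(/C=C/c1ccc(N2CCCC2)cc1)c1ccc([N+](=O)[O-])cc1` — > 25000 nM
compound 2 `COc1cc(O)ccc1/C=C/C(=O)c1ccc(N)cc1` — "not determined" (no result reported)
compound 3 `COc1cc(O)ccc1/C=C/C(=O)c1ccc(F)cc1` — 6300 nM

In a functional assay on SNU-638 cells (Homo sapiens) for cytotoxicity, read by MTT assay (a lower number here means a stronger inhibitor, a higher number a weaker inhibitor), compound 1 gives only > 25000 nM, which is a limit of the assay and not a number (the limit of > 25000 nM in this assay, at which 1 of the 3 values shown sits). Compound 2 has no result in this assay. Among the measured compounds shown here, compound 3 gives 6300 nM in this assay; no single-change step links it to compound 1, so the two values show only that one member of the series reaches a measured number while the other does not.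

Compound 4 `O=C(/C=C/c1ccc(N2CCCC2)cc1)c1ccc(O)cc1` differs from compound 1 by hydroxy in place of nitro on an aromatic carbon. For the measured compounds named here, no measured step shows how this change plays out in this assay. The expectation for compound 4 is a modest move toward stronger inhibition, an at least 1.6-fold lower number from compound 1 to compound 4 (0.22 log units; that floor lies within the scatter), though a further limit remains a real possibility. Compound 4 is estimated at 15000 nM, between 3000 nM and 50000 nM.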

Compound 4, half-maximal inhibitory concentration: 620 nM
Compound 4: the middle estimate sits 24-fold (1.38 log units) above what was measured; the whole stated range lies above it.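

On an aromatic carbon para to a large group, hydroxy in place of nitro gives an at least 40-fold lower number from compound 1 to compound 4 (1.60 log units; beyond the scatter) in this assay. Among the compounds shown here, this is the first single-change step, and it shows that this position alone can carry the core of compound 1 from a limit to a measured number. Compound 1 stands at a limit of the assay and not at a number, so the step gives only a floor on the size of the change: the limit of > 25000 nM in this assay, at which 1 of the 4 values shown sits.

The compounds shown leave open whether the step follows from hydroxy entering or from nitro leaving. Going by these compounds, how a carboxylic acid or a nitrile would read at this position also stays open.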